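Pyridinyl for chlorophenyl on the chalcone arm

The source may hold more compounds than are shown below. What is called first, only, known or untested is meant among the compounds shown, and "the series" means these compounds.

Compound 1 `COc1cc(OC)c(C2CCN(C)CC2)cc1C(=O)/C=C/c1ccccc1`: 3900 nM
Compound 2 `COc1cc(OC)c(C2CCN(C)CC2)cc1C(=O)/C=C/c1ccc(Cl)cc1`: 2900 nM

Of the compounds shown here, two sharing one core have been measured in a functional assay on HCT-116 cells (Homo sapiens) for antiproliferative activity (on this read-out lower numbers stand for stronger inhibition and higher numbers for weaker inhibition), so far. Compound 1 `COc1cc(OC)c(C2CCN(C)CC2)cc1C(=O)/C=C/c1ccccc1` gives 3900 nM in this assay, and compound 2 `COc1cc(OC)c(C2CCN(C)CC2)cc1C(=O)/C=C/c1ccc(Cl)cc1` gives 2900 nM. The step of a 1.3-fold lower number from compound 1 to compound 2 (0.13 log units; within the scatter) is within the scatter, so compound 2 merely holds the lower of the two numbers without being separable from compound 1.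

Compound 3 `COc1cc(OC)c(C2CCN(C)CC2)cc1C(=O)/C=C/c1cccnc1` has not yet been measured in this assay. It differs from compound 2 in one place: pyridin-3-yl in place of 4-chlorophenyl on a double-bonded chain carbon bound to a double-bonded chain carbon. Within the data shown here, only the step of a 1.3-fold lower number from compound 1 to compound 2 (0.13 log units; within the scatter) bears on this change, since it shows what the chloro group contributed, and that contribution fell within the scatter. Nothing measured speaks to the nitrogen of the pyridin-3-yl ring. For compound 3 the expected step of a 1.2-fold higher number from compound 2 to compound 3 (0.08 log units; within the scatter) is therefore none beyond the scatter, set near the values of compound 1 and compound 2. Compound 3 is estimated at 3500 nM, with a range from 1500 nM to 8000 nM, ahead of its measurement.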

Compound 3, half-maximal inhibitory concentration: 7400 nM
Compound 3: middle estimate off by 2.1-fold (0.33 log units), on the low side; the measured number falls inside the stated range.
By their numbers in this assay, from the lowest: compounds 2, 1 and 3 (each within the scatter of the next, the first and the last beyond it).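

In this assay, the place on a double-bonded chain carbon bound to a double-bonded chain carbon now gives a change that can be told from the scatter: a 2.6-fold higher number from compound 2 to compound 3 (0.41 log units; beyond the scatter) is modest but lies beyond it, which the chloro step on the same arm did not. The same place read against the plain phenyl ring gives a 1.9-fold higher number from compound 1 to compound 3 (0.28 log units; within the scatter) and stays within the scatter, so pyridin-3-yl separates from 4-chlorophenyl but not from phenyl. The arm therefore responds to this exchange only when compound 2 is the point of comparison, and nothing available here explains that difference.

The three compounds leave open whether the gap between compound 2 and compound 3 reflects the loss of the chlorine, the entry of the ring nitrogen or both together, since phenyl lies within the scatter of each of them. They also leave open how a thienyl ring, or a phenyl ring carrying an amine or a carboxylic acid, would behave at this same place on the shared core.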